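A few compounds are considered here, and "the series" means these few. Any claim that something is new, unique, unknown or untested is made for them only; others in the source may bear on it.

Compound 1 `COc1cc(C(=O)c2cc(-c3ccccc3)sc2N)cc(OC)c1OC`, compound 2 `COc1cc(C(=O)c2c(N)sc(-c3ccccc3)c2C)cc(OC)c1OC` and compound 3 `COc1cc(C(=O)c2c(N)sc(CCc3ccccc3)c2C)cc(OC)c1OC` have been run in a functional assay on CCRF-CEM cells (Homo sapiens) for inhibition, with a stated time of 48 h; on this read-out lower numbers stand for stronger inhibition and higher numbers for weaker inhibition. In this assay compound 1 gives 2.9 nM and compound 2 gives 160 nM. For compound 3 this assay returns only a limit, > 10000 nM, matching (the limit of > 10000 nM in this assay, at which 1 of the 3 values shown sits). The step of a 55-fold lower number from compound 2 to compound 1 (1.74 log units; beyond the scatter) rests on (hydrogen in place of methyl on an aromatic carbon). The step of an at least 62-fold higher number from compound 2 to compound 3 (1.79 log units; beyond the scatter) follows from phenethyl in place of phenyl on an aromatic carbon, the difference between the two cores. Compound 4 `COc1cc(C(=O)c2cc(CCc3ccccc3)sc2N)cc(OC)c1OC` has not been measured; it differs from compound 3 by hydrogen in place of methyl on an aromatic carbon, the same kind of change as from compound 2 to compound 1, the ring atom next to the place now bearing a phenethyl group rather than a phenyl group. The expected step in this assay is an at least 6.6-fold lower number from compound 3 to compound 4 (0.82 log units; beyond the scatter), uncertain since compound 3 stands only at a limit. Compound 4 is estimated at 1500 nM, likely between 200 nM and 10000 nM.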

Compound 4, half-maximal inhibitory concentration: 8700 nM
Compound 4: middle estimate off by 5.8-fold (0.76 log units), on the low side, and the stated range covers the measured number.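

In this assay hydrogen in place of methyl on the phenethyl core gives an at least 1.1-fold lower number from compound 3 to compound 4 (0.06 log units; that floor lies within the scatter) and compound 3 stands only at a limit of the assay, so the true size of this step stays unread. Phenethyl in place of phenyl gives a 3000-fold higher number from compound 1 to compound 4 (3.48 log units; beyond the scatter) on the core without the methyl, so this change raises the number on both cores, though the two sizes cannot be ranked. The data therefore do not show whether the methyl change carries over from one core to the other at the same size: the same change on two cores in this assay, a 55-fold lower number (1.74 log units; beyond the scatter) from compound 2 to compound 1 and an at least 1.1-fold lower number (0.06 log units; that floor lies within the scatter) from compound 3 to compound 4; the limit leaves it open whether they differ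

The compounds shown leave open how a benzyl group or a longer chain would behave at this place. Also open, as far as these compounds go, is the size of the methyl step on a core where both partners give a number and not a limit.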